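Removing the Naphthalen-1-yl Group from Compound 1

A few compounds are considered here, and "the series" means these few. Any claim that something is new, unique, unknown or untested is made for them only; others in the source may bear on it.

In a functional assay on KB cells (Homo sapiens) for antiproliferative activity, read by MTT assay, with a stated time of 48 h (a higher number here means a weaker inhibitor, a lower number a stronger inhibitor), compound 1 `Cn1cc(C2=C(c3nn(CCCN4CCCCC4)c4ncccc34)C(=O)N(c3cccc4ccccc34)C2=O)c2ccccc21` gives 13400 nM. That lies within the scatter of compound 3 `CN(C)CCCn1nc(C2=C(c3cn(C)c4ccccc34)C(=O)N(c3ccccc3)C2=O)c2cccnc21` at 14100 nM and of compound 2 `Cn1cc(C2=C(c3nn(CCCn4ccnc4)c4ncccc34)C(=O)N(c3ccccc3)C2=O)c2ccccc21` at 6800 nM, so compound 1 stands level with both. Compound 4 `Cn1cc(C2=C(c3nn(CCCN4CCCCC4)c4ncccc34)C(=O)NC2=O)c2ccccc21` has hydrogen in place of naphthalen-1-yl on an amide-type nitrogen in a ring. Within the data shown here, no measured step touches this nitrogen. The only one, a 2.1-fold higher number from compound 2 to compound 3 (0.32 log units; beyond the scatter), is modest and changes the chain instead, so it offers just a rough guide to size and none to direction. A modest move towards a lower number is tentatively expected, namely a 1.9-fold lower number from compound 1 to compound 4 (0.28 log units; within the scatter). For compound 4 the estimated value is 7000 nM, with an expected range of 2000 nM to 20000 nM.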

Compound 4, half-maximal inhibitory concentration: 98000 nM
Compound 4: the middle estimate sits 14-fold (1.15 log units) below what was measured; measured number outside the range, above it.
By their numbers in this assay, from the lowest: compounds 2, 1 and 3 (each within the scatter of the next, the first and the last beyond it); then compound 4.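

In this assay the amide-type nitrogen in the five-membered ring proves sensitive: hydrogen in place of naphthalen-1-yl gives a 7.3-fold higher number from compound 1 to compound 4 (0.86 log units; beyond the scatter) and is the only step shown at this position. The number therefore rises, beyond the scatter, when the two six-membered aromatic rings of naphthalen-1-yl leave this nitrogen. Nothing at hand accounts for this rise. The compounds shown leave open whether a smaller group on this nitrogen, such as methyl or benzyl, would keep the number nearer that of compound 1.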